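A few compounds are considered here, and "the series" means these few. Any claim that something is new, unique, unknown or untested is made for them only; others in the source may bear on it.

Compound 1 `COc1cc(-c2cc(/C=C/C(=O)c3ccc(N)cc3)[nH]n2)cc(OC)c1OC` and compound 2 `COc1ccc(-c2cc(/C=C/C(=O)c3ccc(OC)c(OC)c3)[nH]n2)cc1` share one core and were both read in a functional assay on SK-MEL-5 cells (Homo sapiens) for cytotoxicity, read by sulforhodamine B assay, with a stated time of 48 h, tested at 0.01 uM; on this read-out lower numbers stand for a stronger effect and higher numbers for a weaker effect at the one concentration tested. Compound 1 gives 95%; compound 2 gives 90%, a number within the usual scatter of the first, so the two read alike and neither stands apart. Compound 3 `COc1cc(-c2cc(/C=C/C(=O)c3ccc(Cl)c(Cl)c3)[nH]n2)cc(OC)c1OC` differs from compound 1 by 3,4-dichlorophenyl in place of 4-aminophenyl on a carbonyl carbon. Within the data shown here, no step between measured compounds shows how this change acts; since both measured values sit near the top of the read-out, the expectation is no change beyond the scatter, with an expected step of a number 5 percentage points lower from compound 1 to compound 3 (within the scatter). Compound 3 is thus estimated at 90%, in a range of 70% to 100%.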

Compound 3, a percentage reported as activity, at one concentration (the size of the read-out at that concentration, not a potency): 98%
The estimate for compound 3 lay 8 percentage points below the measured number; the measured number falls inside the stated range.
By their numbers in this assay, from the lowest: compounds 2, 1 and 3 (each within the scatter of the next).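

In this assay, among these compounds, 3,4-dichlorophenyl in place of 4-aminophenyl on a carbonyl carbon gives a number 3 percentage points higher from compound 1 to compound 3 (within the scatter) and is the only step read at this position. At this one concentration, the read-out does not separate an aryl group carrying a hydrogen-bond donor and acceptor from one carrying neither. No measured evidence bears on this result.

On these data alone, whether a carboxylic acid or a longer chain bearing an amine on this carbonyl carbon would separate from compound 1 remains open. So does any effect of changing the trimethoxy-substituted side of the shared core.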